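The compounds below may be only part of what the source reports. "The series", "measured", "known", "first", "only" and "open" are said of these compounds alone.

Compound 1, `C=CCSc1nnc(CC)n1N1C(=O)c2ccccc2C1=O`: in a functional assay on A549 cells (Homo sapiens) for cytotoxicity, read by MTT assay, with a stated time of 48 h (on this read-out higher numbers stand for weaker inhibition and lower numbers for stronger inhibition), compound 1 gives > 200000 nM, which is a limit of the assay and not a number.
Compound 2, `CCc1nnc(SC)n1N1C(=O)c2ccccc2C1=O`: in this assay compound 2 gives > 200000 nM, again a limit and not a number.

Compound 2 therefore stands only at a limit in this assay, namely (the limit of > 200000 nM in this assay, at which 2 of the 2 values shown sit). Going by the values given here, the single measured step, a step that the two limits leave unreadable from compound 1 to compound 2, cannot be read in size or direction because the limit of > 200000 nM in this assay, at which 2 of the 2 values shown sit, bounds both of its ends. Compound 3, `CCOC(=O)CSc1nnc(CC)n1N1C(=O)c2ccccc2C1=O`, differs from compound 2 by ethoxycarbonyl in place of hydrogen on a saturated chain carbon bound to a sulfur. Among the compounds with values here, no measured step bears on this change, and the one step available gives no size at all. Compound 3 is thus expected to stay at the limit as well, with an estimate of 200000 nM and a range from 50000 nM to 800000 nM. The step of a number no higher from compound 2 to compound 3 (the limit leaves the size open) that this estimate means is expected to be none beyond the scatter, and most likely only a limit will be reported.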

Compound 3, half-maximal inhibitory concentration: > 200000 nM
Compound 3 was reported as a limit; the forecaster's own chance of this, stated with the estimate: 80%; the middle value lies on the limit itself.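

Going by these compounds alone, no step among compound 1, compound 2 and compound 3 can be read in size or direction, because each of them gives a limit and not a number: the limit of > 200000 nM in this assay, at which 3 of the 3 values shown sit. The compounds shown leave open whether any group on the saturated chain carbon bound to a sulfur can give a measurable value in this assay.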